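The source may hold more compounds than are shown below. What is called first, only, known or untested is meant among the compounds shown, and "the series" means these compounds.

Compound 1 `Cc1nnc(-c2ccc(-c3ccccn3)cc2)n1-c1ccccc1F`: 860 nM
Compound 2 `CCc1nnc(-c2ccc(-c3ccccc3)cc2)n1-c1cccc(CO)c1C`: 250 nM

In an assay on C6 glioma cells for displacement of a labelled ligand from sodium- and chloride-dependent glycine transporter 1 (Rattus norvegicus), read by scintillation counting, with stated times of 30 min and 10 min (a higher number here means a weaker inhibitor, a lower number a stronger inhibitor), compound 2 holds the lowest of the two numbers; compound 1 stands at a higher number, a gap beyond the usual scatter. Compound 3 `CCc1nnc(-c2ccc(-c3ccccc3)cc2)n1-c1cccc(C(N)=O)c1C` has not been measured. It differs from compound 2 by carbamoyl in place of hydroxymethyl on an aromatic carbon. The leaving and the entering group each carry one hydrogen-bond donor and one hydrogen-bond acceptor, and the step from compound 2 to compound 3 is expected to be small, a 1.2-fold higher number from compound 2 to compound 3 (0.08 log units; within the scatter), within the scatter in either direction. Compound 3 is therefore estimated at 300 nM, with a range from 100 nM to 900 nM.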

Compound 3, half-maximal inhibitory concentration: 3900 nM
For compound 3 the middle estimate is 13-fold (1.11 log units) below the measured one; the measured number lies above the stated range.
By their numbers in this assay, from the lowest: compound 2; then compound 1; then compound 3.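

In this assay, the aromatic carbon ortho to a methyl group and meta to a large group proves sensitive to the group it carries: carbamoyl in place of hydroxymethyl gives a 16-fold higher number from compound 2 to compound 3 (1.19 log units; beyond the scatter). The leaving and the entering group have the same hydrogen-bond donor and acceptor counts, so those counts alone do not make them interchangeable here. Nothing available accounts for this gap. Going by these compounds, whether an amine, a carboxylic acid or a methoxy group on this carbon would stay near hydroxymethyl or near carbamoyl remains open.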